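Compound 1 to compound 4: losing the aromatic ring

This account rests on a few compounds, and the source may have more. Where it says the series, first, only, none or still open, it means among the compounds named here.

Measured in an ADME assay on MRC5 cells (Homo sapiens) for inhibition, with a stated time of 72 h; a higher number here means that more compound is needed for the effect, a lower number that less compound is needed:
- compound 1 `CO[C@H]1CC[C@H](NC(=O)c2n[nH]cc2NC(=O)c2cc(Cl)cc(Cl)c2)CC1`: 13000 nM
- compound 2 `COc1cccc(OC)c1C(=O)Nc1c[nH]nc1C(=O)NCC1CCCCC1`: > 50000 nM (a limit)
- compound 3 `COc1cccc(OC)c1C(=O)Nc1c[nH]nc1C(=O)Nc1ccccn1`: > 50000 nM (a limit)

Within the data shown here, compound 1, at 13000 nM, holds the only true number in this set. The other two entries are limits and not numbers, as the set shows in the limit of > 50000 nM in this assay, at which 2 of the 3 values shown sit. Compound 1 therefore has no measured value to be ranked against.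

Compound 4 `CO[C@H]1CC[C@H](NC(=O)c2n[nH]cc2NC(=O)C2CCC(F)(F)CC2)CC1` keeps the core of compound 1 and changes one group: 4,4-difluorocyclohexyl in place of 3,5-dichlorophenyl on a carbonyl carbon. This puts 4,4-difluorocyclohexyl in place of 3,5-dichlorophenyl on a carbonyl carbon, so a non-aromatic ring replaces an aromatic one.

Among the measured compounds shown here, the only measured step, a step that the two limits leave unreadable from compound 2 to compound 3, offers little guidance. It lies on an amide-type nitrogen and not on this carbonyl carbon, and no size can be read from it. For the measured compounds named here, no measured step covers the exchange itself, so the expectation rests on the values alone. Going by the values given here, the only compound here with 3,5-dichlorophenyl is also the only one to give a number, compound 1 at 13000 nM, and one compound makes no pattern.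

A moderate rise is expected, with more compound needed in this assay, and the estimated step is a 2.7-fold higher number from compound 1 to compound 4 (0.43 log units; beyond the scatter). A report at the limit would fit this expectation. For compound 4 the estimate is 35000 nM, with an expected range of 15000 nM to 60000 nM.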

Compound 4, half-maximal effective concentration: > 50000 nM
Compound 4 ended at the assay's limit; the forecaster's own chance of this, stated with the estimate: 45%; middle value at least 1.4-fold (0.15 log units) from the limit.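

In this assay compound 4 gives > 50000 nM, which is a limit and not a number. Among these compounds, with the shared core held fixed, the exchange of 3,5-dichlorophenyl for 4,4-difluorocyclohexyl on a carbonyl carbon is an at least 3.8-fold higher number from compound 1 to compound 4 (0.58 log units; beyond the scatter), the first readable step, so the group at this place does change the read-out in this assay. The step is only a lower bound, and the series as a whole is dominated by this ceiling: the limit of > 50000 nM in this assay, at which 3 of the 4 values shown sit.

The compounds shown do not separate the loss of the aromatic ring from the exchange of chlorine for fluorine, since the two groups differ in both, and plain phenyl or unsubstituted cyclohexyl on this carbonyl carbon would speak to that question. Going by these compounds, how far compound 4 lies past the limit also stays open, as does the effect of a group such as 3,5-dimethylphenyl here, and the remaining step, which joins two limits, cannot be read.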